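The compounds below may be only part of what the source reports. "The series", "measured", "known", "first", "only" and "open" are said of these compounds alone.

Compound 1 `CCCCCCCCCCCCCCn1cc(COC[C@@H]2OC[C@H](N)[C@@H]2O)nn1` gives the lower of the two numbers measured in a functional assay on MCF7 cells (Homo sapiens) for antiproliferative activity, read by MTT assay, with a stated time of 48 h (a lower number here means a stronger inhibitor, a higher number a weaker inhibitor), where compound 1 gives 1850 nM. For the measured compounds named here, compound 2 `CCCCCCCCCCCCCCCCCCn1cc(COC[C@@H]2OC[C@H](N)[C@@H]2O)nn1` carries a longer chain, and in this assay compound 2 gives 7580 nM; the only measured step is a 4.1-fold higher number from compound 1 to compound 2 (0.61 log units; beyond the scatter). Compound 3 `CCCCCCCCCCCCCCn1cc(COC[C@@H]2OC[C@H](N)[C@H]2O)nn1` is a stereoisomer of compound 1: the two compounds have the same atoms and bonds and differ only in configuration as drawn: 1 of 3 stereo elements differ; a stereocentre at a saturated ring carbon is drawn S in compound 1 and R in compound 3. Going by the values given here, the one measured step concerns lengthening the chain, not configuration, so it does not bear on this change, and nothing measured shows how the shared core responds to an inverted stereocentre. The expectation therefore rests on compound 1 alone and must carry a wide range. Compound 3 is expected to give an estimated 2500 nM in this assay, between 700 nM and 9000 nM. The step this estimate means, a 1.4-fold higher number from compound 1 to compound 3 (0.13 log units; within the scatter), is expected to fall within the scatter, with real uncertainty in either direction.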

Compound 3, half-maximal inhibitory concentration: 2450 nM
Beside the measured number, compound 3's estimate is 1.0-fold (0.01 log units) above it; measured number inside the range.
By their numbers in this assay, from the lowest: compounds 1 and 3 (each within the scatter of the next); then compound 2.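

In this assay, changing a stereocentre at a saturated ring carbon from S to R gives a 1.3-fold higher number from compound 1 to compound 3 (0.12 log units; within the scatter), so the two configurations cannot be told apart by this read-out. For the compounds shown here, until now, the only measured change was in the chain, which gave a 4.1-fold higher number from compound 1 to compound 2 (0.61 log units; beyond the scatter); this new step shows that the number need not respond to every change in the molecule, at least for this one stereocentre with this chain. The result can be read as a pure test of configuration for one reason: the fact that compounds 1 and 3 differ only in the configuration as drawn.

On these data alone, it remains open whether the other two stereo elements are equally tolerated, or whether this stereocentre would matter with the longer chain of compound 2. As far as these compounds go, the effect of a shorter chain, or of an acetyl group on the amine, also remains open.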